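The source may hold more compounds than are shown below. What is called first, only, known or untested is meant among the compounds shown, and "the series" means these compounds.

Compound 1 `COc1cc(OC)c2c(=O)cc(-c3ccc(OCCBr)cc3)oc2c1` is the starting point. In a functional assay (Homo sapiens) for antiproliferative activity, read by resazurin assay, with a stated time of 48 h, tested at 10 uM (a higher number here means a stronger effect of the compound at the concentration tested, a lower number a weaker effect), compound 1 gives "not active" (no number reported), so no single number stands for it. Two related compounds carry numbers: compound 2 `COc1cc(OC)c2c(=O)cc(-c3ccc(OCCCN(C)C)cc3)oc2c1` gives 59% in this assay, and compound 3 `COc1cc(OC)c2c(=O)cc(-c3ccc(OC4CCNCC4)cc3)oc2c1` gives 21%. For the measured compounds named here, the one step between them, a number 38 percentage points lower from compound 2 to compound 3 (beyond the scatter), concerns the group attached to an oxygen on an aromatic ring. Compound 4 `COc1cc(OC)c2c(=O)cc(-c3ccc(OCC(O)CO)cc3)oc2c1` differs from compound 1 in 1,2-dihydroxyethyl in place of bromomethyl on a saturated chain carbon bound to an oxygen on an aromatic ring. Going by the values given here, no measured step matches this change, and compound 1 offers no number to step from; the step from compound 2 to compound 3 shows only that a change at such an oxygen came with a large step. Compound 4 is therefore expected to give about 15% in this assay, within 0% to 40%.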

Compound 4, a percentage reported as inhibition, at one concentration (the size of the read-out at that concentration, not a potency): 11%
Compound 4: middle estimate off by 4 percentage points, on the high side; the range from low to high includes it.
By their numbers in this assay, from the lowest: compounds 4 and 3 (each within the scatter of the next); then compound 2.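

In this assay, 2,3-dihydroxypropyl on the oxygen gives a number close to that of the piperidin-4-yl group (a number 10 percentage points lower from compound 3 to compound 4 (within the scatter)), while 1,2-dihydroxyethyl in place of 2-(dimethylamino)ethyl at the saturated chain carbon gives a much smaller one (a number 48 percentage points lower from compound 2 to compound 4 (beyond the scatter)). Among the compounds with numbers, only compound 2 stands clearly apart. Nothing measured here explains these differences.

The step from compound 1 cannot be read, as it has no number. As far as these compounds go, whether a carboxylic acid or a longer chain ending in a dimethylamino group would fit at this oxygen remains open.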